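The source may hold more compounds than are shown below. What is called first, only, known or untested is meant among the compounds shown, and "the series" means these compounds.

Measured compounds in a functional assay on the whole organism (blood, strain Wistar-Okamoto) with Rattus norvegicus as the target, with a stated time of 5 days; on this read-out lower numbers stand for an effect already at smaller amounts and higher numbers for an effect only at larger amounts of compound: compound 1 `CC(C)C/N=C(\NC#N)Nc1cccnc1` gives 20 mg/kg; compound 2 `CC(C)/N=C(\NC#N)Nc1cccnc1` gives 2.5 mg/kg; compound 3 `CC(C)C(C)(C)/N=C(\NC#N)Nc1cccnc1` gives 1 mg/kg.

Compound 3 stands lowest of the three numbers in this assay. Its nearest neighbour is compound 2, through the step of a 2.5-fold lower number from compound 2 to compound 3 (0.40 log units; beyond the scatter), and its furthest is compound 1, through the step of a 20-fold lower number from compound 1 to compound 3 (1.30 log units; beyond the scatter); both steps lie beyond the scatter.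

Compound 4 `C=C(C)C/N=C(\NC#N)Nc1cccnc1` differs from compound 3 in one place: 2-methylprop-2-en-1-yl in place of 1,1,2-trimethylpropyl on a double-bonded nitrogen. Among the measured compounds shown here, the steps that bear on this change are the ones in which only the group on the double-bonded nitrogen was exchanged: an 8.0-fold lower number from compound 1 to compound 2 (0.90 log units; beyond the scatter) and a 20-fold lower number from compound 1 to compound 3 (1.30 log units; beyond the scatter). In both, the number fell as the group moved away from isobutyl, and a 2.5-fold lower number from compound 2 to compound 3 (0.40 log units; beyond the scatter) points the same way. The 2-methylprop-2-en-1-yl group of compound 4 has four carbon, like the isobutyl of compound 1, and no branching at the carbon bound to the nitrogen, unlike the 1,1,2-trimethylpropyl of compound 3. For the measured compounds named here, the expected step is therefore a higher number in this assay, roughly undoing a 20-fold lower number from compound 1 to compound 3 (1.30 log units; beyond the scatter), though the double bond has no measured counterpart here.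

Compound 4 is expected to give about 12 mg/kg, within the range 4 mg/kg to 40 mg/kg. This estimate corresponds to an expected step of a 12-fold higher number from compound 3 to compound 4 (1.08 log units; beyond the scatter).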

Compound 4, minimum effective dose: 20 mg/kg
For compound 4 the middle estimate is 1.7-fold (0.22 log units) below the measured one; the measured number falls inside the stated range.
By their numbers in this assay, from the lowest: compound 3; then compound 2; then compounds 1 and 4 (each within the scatter of the next).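

In this assay, 2-methylprop-2-en-1-yl on the double-bonded nitrogen gives up the gains of the two lower compounds, with a 20-fold higher number from compound 3 to compound 4 (1.30 log units; beyond the scatter) and an 8.0-fold higher number from compound 2 to compound 4 (0.90 log units; beyond the scatter). What is new is that the double bond makes no visible difference against the saturated group: exchanging isopropyl for 1-methylethenyl on the saturated chain carbon gives no change at the digits printed from compound 1 to compound 4 (within the scatter), so the isobutyl and 2-methylprop-2-en-1-yl compounds sit together, both above the isopropyl and 1,1,2-trimethylpropyl compounds. Nothing on hand accounts for this grouping of the four compounds.

The compounds shown leave open where a tert-butyl group, a cyclopropyl ring or a straight pentyl chain on the double-bonded nitrogen would fall relative to these two pairs. They also leave open whether a hydroxyl or an amine on such a chain would shift the number, and whether the match between the saturated group and its double-bonded counterpart would hold for a group other than isobutyl.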